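A few compounds are considered here, and "the series" means these few. Any claim that something is new, unique, unknown or untested is made for them only; others in the source may bear on it.

Working notes on the series. Compound 3 `COc1cc(Cl)cc(-c2nn(-c3cccc(NC(=O)Nc4ccc(Cl)c(Cl)c4)c3)cc2-c2ccncc2)c1` gives 0.46% in a functional assay on MDA-MB-435 cells (Homo sapiens) for inhibition, read by sulforhodamine B assay, with a stated time of 48 h, tested at 10 uM (a lower number here means a stronger effect, a higher number a weaker effect of the compound at the concentration tested), the second highest of the three numbers: compound 2 `COc1cc(Cl)cc(-c2nn(-c3cccc(NC(=O)Nc4cc(C(F)(F)F)cc(C(F)(F)F)c4)c3)cc2-c2ccncc2)c1` gives -19.5% and compound 1 `COc1cc(Cl)cc(-c2nn(-c3cccc(NC(=O)c4ccc(Cl)c(Cl)c4)c3)cc2-c2ccncc2)c1` gives 80.8%. For the measured compounds named here, the one measured step, a number 80.3 percentage points lower from compound 1 to compound 3 (beyond the scatter), concerns the (3,4-dichlorophenyl)amino in place of 3,4-dichlorophenyl on a carbonyl carbon, not the aryl group on the urea, so it does not bear on the next change. Compound 4 `COc1cc(Cl)cc(-c2nn(-c3cccc(NC(=O)Nc4cccc(C(F)(F)F)c4)c3)cc2-c2ccncc2)c1` differs from compound 3 by 3-(trifluoromethyl)phenyl in place of 3,4-dichlorophenyl on an amide-type nitrogen. Compounds 2 and 3, both ureas with different aryl groups, sit within a modest gap of each other near zero. A step of little size beyond the scatter is therefore expected, a number 5.5 percentage points lower from compound 3 to compound 4 (within the scatter). Compound 4 is estimated at -5%, between -30% and 25%.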

Compound 4, a percentage reported as activity, at one concentration (the size of the read-out at that concentration, not a potency): -20.9%
Estimate against measurement, compound 4: 15.9 percentage points above; measured number inside the range.
By their numbers in this assay, from the lowest: compounds 4 and 2 (each within the scatter of the next); then compound 3; then compound 1.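

On the amide-type nitrogen of the urea, 3-(trifluoromethyl)phenyl in place of 3,4-dichlorophenyl gives a number 21.4 percentage points lower from compound 3 to compound 4 (beyond the scatter) in this assay, so this aryl group does move the read-out among ureas. Hydrogen in place of one trifluoromethyl on an aromatic carbon gives only a number 1.4 percentage points lower from compound 2 to compound 4 (within the scatter), leaving the two trifluoromethyl-bearing ureas level. The large gap to the amide also appears with this aryl group, a number 101.7 percentage points lower from compound 1 to compound 4 (beyond the scatter), as it did with 3,4-dichlorophenyl.

No measurement offers an explanation for these steps. From the compounds shown here alone, whether a nitrile or a carboxylic acid in place of trifluoromethyl on that aromatic carbon would keep the read-out at this level remains open.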